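Changing the Amine at the End of the Side Chain

This account rests on a few compounds, and the source may have more. Where it says the series, first, only, none or still open, it means among the compounds named here.

Measured compounds in a functional assay on HepG2 cells (Homo sapiens) for antiproliferative activity, read by MTT assay, with a stated time of 48 h; on this read-out higher numbers stand for weaker inhibition and lower numbers for stronger inhibition:
compound 1 `O=c1cc(-c2ccccc2)oc2cc(OCc3ccccc3)c(OCCCN3CCCC3)c(O)c12` gives 4200 nM
compound 2 `COc1cc2oc(-c3ccccc3)cc(=O)c2c(O)c1OCCCN1CCCC1` gives 4300 nM
compound 3 `O=c1cc(-c2ccccc2)oc2cc(O)c(OCCCN3CCCC3)c(O)c12` gives only a limit, > 100000 nM

Compound 1 has the lowest of the two numbers, and compound 2 sits within the scatter of it (a 1.0-fold higher number from compound 1 to compound 2 (0.01 log units; within the scatter)). For compound 3 only a limit is reported: the limit of > 100000 nM in this assay, at which 1 of the 3 values shown sits. Removing the benzyl from the oxygen on the aromatic ring gives an at least 23-fold higher number from compound 1 to compound 3 (1.37 log units; beyond the scatter), and removing the methyl gives an at least 23-fold higher number from compound 2 to compound 3 (1.36 log units; beyond the scatter), both large. Compound 4 `CCN(CC)CCCCOc1c(OCc2ccccc2)cc2oc(-c3ccccc3)cc(=O)c2c1O` differs from compound 1 only in the amine: (diethylamino)methyl in place of pyrrolidin-1-yl on a saturated chain carbon, three bonds along the chain from an oxygen on an aromatic ring. Within the data shown here, none of the measured steps touches this part of the chain, so no change beyond the scatter is expected; the step is estimated as a 1.1-fold higher number from compound 1 to compound 4 (0.03 log units; within the scatter). Compound 4 is therefore expected to give 4500 nM, in the range 2000 nM to 10000 nM.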

Compound 4, half-maximal inhibitory concentration: 2200 nM
For compound 4 the middle estimate is 2.0-fold (0.31 log units) above the measured one, within the range that was stated.
By their numbers in this assay, from the lowest: compounds 4, 1 and 2 (each within the scatter of the next). At a limit, above all of these: compound 3.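

In this assay, replacing the pyrrolidin-1-yl ring with the open (diethylamino)methyl group gives a 1.9-fold lower number from compound 1 to compound 4 (0.28 log units; within the scatter) and so stays within the scatter. The amine end of the side chain therefore accepts an open amine with one more carbon, unlike the oxygen on the aromatic ring, where removing the benzyl or methyl produced the large steps. Nothing measured here bears on why this amine change makes so little difference. As far as these compounds go, because ring opening and added carbon arrive together, their separate contributions remain unknown. From the compounds shown here alone, a morpholine ring, a primary amine or a carboxylic acid at this chain end remains open.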